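Series notes: methyl added on the valine-type side chain

The source may report more compounds than this note shows. Statements on the series, on what has been measured and on what is new or still open speak of the compounds shown alone.

Among the measured compounds shown here, compound 2 `COc1cc(NC(C)CCCN2C(=O)CN(C(=O)[C@H](N)C(C)C)C2(C)C)c2ncccc2c1` stands at the lower of the two numbers so far in a physicochemical assay for lipophilicity, measured as octanol-water partition (on this read-out higher numbers stand for higher lipophilicity and lower numbers for lower lipophilicity), where compound 2 gives 2.93. For the measured compounds named here, its only neighbour, compound 1 `COc1cc(NC(C)CCCN2C(=O)CN(C(=O)[C@H](N)CCSC)C2(C)C)c2ncccc2c1`, gives 2.94 in this assay; the step of a number 0.01 log units lower from compound 1 to compound 2 (within the scatter) lies within the scatter, so the two compounds cannot be ordered against each other on this read-out.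

Compound 3 `CC[C@H](C)[C@@H](N)C(=O)N1CC(=O)N(CCCC(C)Nc2cc(OC)cc3cccnc23)C1(C)C` differs from compound 2 by methyl in place of hydrogen on a saturated chain carbon, three bonds along the chain from an amine nitrogen and a carbonyl carbon. Going by the values given here, the one measured step concerns a different exchange at the carbon bound to the amine nitrogen and the carbonyl carbon, not the addition of a methyl further out on the chain, so it gives no direct guide to the size of the present step. It does show that a swap of one saturated side chain for another left this assay essentially flat. Adding one carbon with no donor, no acceptor and no charge would ordinarily be expected to raise the partition coefficient by a small amount, beyond the scatter but not by much. The expected step is a number 0.42 log units higher from compound 2 to compound 3 (beyond the scatter). Compound 3 is therefore estimated at 3.35, with a range from 3.05 to 3.65.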

Compound 3, partition coefficient: 3.4
Compound 3: the middle estimate sits 0.05 log units below what was measured, and the stated range covers the measured number.
By their numbers in this assay, from the lowest: compounds 2 and 1 (each within the scatter of the next); then compound 3.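

Methyl in place of hydrogen on a saturated chain carbon, three bonds along the chain from an amine nitrogen and a carbonyl carbon, gives a step in this assay that lies beyond the scatter (a number 0.47 log units higher from compound 2 to compound 3 (beyond the scatter)), so this outer part of the side chain is not silent on this read-out. The flat result for isopropyl in place of 2-(methylsulfanyl)ethyl therefore does not extend to every saturated side chain at the carbon bound to the amine nitrogen and the carbonyl carbon, since sec-butyl in place of the same group gives a step beyond the scatter (a number 0.46 log units higher from compound 1 to compound 3 (beyond the scatter)). Nothing given here accounts for the size of either step.

Whether the number keeps rising with a longer chain at this place, or falls with a hydroxyl or a carboxylic acid at the end of the chain, cannot be read from the compounds shown. Going by these compounds, with a single pair for this methyl exchange, it also remains open whether the same exchange would give a step of similar size on another side chain or on another core.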